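The compounds below may be only part of what the source reports. "The series", "measured", "known", "first", "only" and "open" are said of these compounds alone.

Compound 1 `CSc1nnc(-c2ccccc2F)n1C` and compound 2 `Cn1c(-c2ccccc2F)nnc1[S+](C)[O-]` share one core and differ in a single place: a group of 3 heavy atoms (1 carbon, 1 oxygen, 1 sulfur; no ring) in place of a group of 2 heavy atoms (1 carbon, 1 sulfur; no ring), on an aromatic carbon. In a functional assay on the whole organism for antagonist activity, with Mus musculus as the target (a higher number here means that more compound is needed for the effect, a lower number that less compound is needed), compound 1 gives 61.3 mg/kg. In this assay compound 2 gives 57.9 mg/kg, so the step of a 1.1-fold lower number from compound 1 to compound 2 (0.02 log units; within the scatter). Compound 3 `CSc1nc(-c2ccccc2)n(C)n1` rests on another core, and the difference between the two cores is not broken down here. In this assay compound 3 gives only a limit, not a number, > 100 mg/kg (the limit of > 100 mg/kg in this assay, at which 1 of the 3 values shown sits). Compound 4 `Cn1nc([S+](C)[O-])nc1-c1ccccc1` is unmeasured and differs from compound 3 by a group of 3 heavy atoms (1 carbon, 1 oxygen, 1 sulfur; no ring) in place of a group of 2 heavy atoms (1 carbon, 1 sulfur; no ring), on an aromatic carbon, the same kind of change as above, made twice among these compounds, though here placed two ring bonds from the ring atom that bears a methyl group and two ring bonds from the ring nitrogen. Because a 1.1-fold lower number from compound 1 to compound 2 (0.02 log units; within the scatter) lay within the scatter, a similar small step is expected for compound 4, a step that the limit leaves unreadable from compound 3 to compound 4. Compound 4 is therefore estimated at 120 mg/kg, between 55 mg/kg and 260 mg/kg, and may again return only a limit.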

Compound 4, dose for half-maximal effect: > 200 mg/kg
Compound 4: a limit, no number (the forecaster's own chance of this, stated with the estimate: 60%); middle value at least 1.6-fold (0.22 log units) from the limit.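

Compound 3 and compound 4 each give only a limit in this assay, and the step between them cannot be read. The compounds shown leave open what dose either one actually needs, and whether replacing methylsulfanyl changes anything on this core.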